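Extending the Ethoxy Chain on a Shared Core

The source may report more compounds than this note shows. Statements on the series, on what has been measured and on what is new or still open speak of the compounds shown alone.

Of the compounds shown here, three sharing one core have been measured. Compound 1 `CCCC1=C(OCC(C)C)C(CCC)(CCC)C(=O)/C(=C(O)\C=C\c2ccccc2)C1=O` gives 13.4 uM in a functional assay on HepG2 cells (Homo sapiens) for antiproliferative activity, read by sulforhodamine B assay, with a stated time of 3 days; a higher number here means that more compound is needed for the effect, a lower number that less compound is needed. Compound 2 `CCCC1=C(OC)C(CCC)(CCC)C(=O)/C(=C(O)\C=C\c2ccc(I)cc2)C1=O`, which carries an iodine on its phenyl ring and a methoxy group, gives 2.4 uM in this assay, and compound 3 `CCCC1=C(OCC)C(CCC)(CCC)C(=O)/C(=C(O)\C=C\c2ccccc2)C1=O` gives 11.2 uM. Among these three numbers compound 3 stands second highest; its nearest neighbour is compound 1, and the two lie within the scatter of each other, while compound 2 sits at a clearly lower number, though compound 2 differs from compound 3 in more than one place, so its values alone cannot be tied to a single change.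

Going by the values given here, the one single-point step on record, a 1.2-fold lower number from compound 1 to compound 3 (0.08 log units; within the scatter), replaces isopropyl by methyl on the saturated chain carbon bound to the oxygen and changes the number by no more than the scatter. Compound 4 `CCCC1=C(OCCC(C)C)C(CCC)(CCC)C(=O)/C(=C(O)\C=C\c2ccccc2)C1=O` goes the other way along the same chain: isopropyl in place of hydrogen on a saturated chain carbon, two bonds along the chain from an oxygen on an unsaturated carbon. Since compound 1 showed 13.4 uM with a longer branched chain at this oxygen, no step beyond the scatter is expected. Compound 4 is expected to give about 11 uM, within 5 uM to 25 uM. This corresponds to an expected step of a 1.0-fold lower number from compound 3 to compound 4 (0.01 log units; within the scatter).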

Compound 4, concentration for half-maximal effect: 15.5 uM
Estimate against measurement, compound 4: 1.4-fold (0.15 log units) below; the measured number falls inside the stated range.
By their numbers in this assay, from the lowest: compound 2; then compounds 3, 1 and 4 (each within the scatter of the next).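

Adding isopropyl to the ethoxy chain gives a 1.4-fold higher number from compound 3 to compound 4 (0.14 log units; within the scatter) in this assay, and replacing the isopropyl on the saturated chain carbon bound to the oxygen with isobutyl gives a 1.2-fold higher number from compound 1 to compound 4 (0.06 log units; within the scatter). Going by these compounds alone, the earlier compounds offered only one step at this oxygen, so this result adds a second and a third comparison, and all of them stay within the scatter: with the rest of the core and the unsubstituted phenyl ring held constant, the ethoxy, isobutyloxy and isopentyloxy versions cannot be told apart in this assay. No measurement shown explains why these chains make so little difference to the number.

The compounds shown leave open whether a longer chain, or an amine or a carboxylic acid in place of the isopentyl group, would shift the number beyond the scatter. Within the data shown here, they also leave open how much of the lower number of compound 2, which has a methoxy group and an iodine on its phenyl ring, belongs to either feature, since no single-place step connects it to the other compounds.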